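A few compounds are considered here, and "the series" means these few. Any claim that something is new, unique, unknown or untested is made for them only; others in the source may bear on it.

In a functional assay on SK-MEL-5 cells (Homo sapiens) for antiproliferative activity (on this read-out higher numbers stand for weaker inhibition of growth and lower numbers for stronger inhibition of growth), compound 1 `Cc1cc(C)c2c(O)cc(-c3cccc(F)c3)nc2n1` gives 37.2 nM. Among the compounds with values here, the only other measured compound, compound 2 `Cc1cnc2[nH]c(-c3cccc(Cl)c3)cc(=O)c2c1`, gives 70.8 nM, so the two numbers lie within the usual scatter of each other. Compound 3 `Cc1cccc(-c2cc(O)c3c(C)cc(C)nc3n2)c1` differs from compound 1 in one place: methyl in place of fluoro on an aromatic carbon. Within the data shown here, no measured pair of compounds shows this change, so the data offer no direct guide to its size or direction. The expected step, a 1.3-fold higher number from compound 1 to compound 3 (0.13 log units; within the scatter), is therefore none beyond the scatter. Compound 3 is estimated at 50 nM, with an expected range of 15 nM to 170 nM.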

Compound 3, concentration for 50% growth inhibition: 34700 nM
Compound 3: the middle estimate sits 690-fold (2.84 log units) below what was measured; measured number outside the range, above it.
By their numbers in this assay, from the lowest: compounds 1 and 2 (each within the scatter of the next); then compound 3.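

In this assay, methyl in place of fluoro on an aromatic carbon, meta to a large group, gives a 930-fold higher number from compound 1 to compound 3 (2.97 log units; beyond the scatter). This position is therefore far from indifferent to which small group it carries, even though the two groups each have one heavy atom and neither brings a hydrogen-bond donor or acceptor. Nothing available explains why these two groups differ so sharply. As far as these compounds go, it remains open whether an amine or a methoxy group at this place would keep the strong growth inhibition of compound 1 or lose it as compound 3 does.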